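Replacing formyl with (pyrrolidin-1-yl)methyl on the shared core

This account rests on a few compounds, and the source may have more. Where it says the series, first, only, none or still open, it means among the compounds named here.

Three compounds built on one core have numbers in a functional assay on MCF7 cells (Homo sapiens) for antiproliferative activity, read by MTT assay, with a stated time of 48 h; a higher number here means a weaker inhibitor, a lower number a stronger inhibitor. There compound 3 `CC(C)=CCC[C@]1(C)/C=C/[C@@H](OC(=O)C=C(C)C)[C@](C)(O)/C=C/C(=O)/C(C=O)=C\C1` gives 12600 nM, and compound 2 `COC/C1=C/C[C@](C)(CCC=C(C)C)/C=C/[C@@H](OC(=O)C=C(C)C)[C@](C)(OC)/C=C/C1=O` gives 16500 nM, the two values lying within the scatter of each other. Compound 1 `CC(=O)OC/C1=C/C[C@](C)(CCC=C(C)C)/C=C/[C@@H](OC(=O)C=C(C)C)[C@](C)(OC(C)=O)/C=C/C1=O` gives 3990 nM, a lower number than the other two and beyond the scatter from both, which marks it as the stronger inhibitor of the three.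

Compound 4 `CC(C)=CCC[C@]1(C)/C=C/[C@@H](OC(=O)C=C(C)C)[C@](C)(O)/C=C/C(=O)/C(CN2CCCC2)=C\C1` has not yet been measured. It keeps the core of compound 3 and changes one group, with (pyrrolidin-1-yl)methyl in place of formyl on a double-bonded ring carbon. Among the measured compounds shown here, no measured pair isolates this change, as any two of the three measured compounds differ in more than one place. The evidence is therefore thin, and the expectation rests on the span of the measured numbers, with compound 1 at 3990 nM and compound 2 at 16500 nM. A small move toward a lower number in this assay is expected, though none beyond the scatter, and the estimated change is a 1.4-fold lower number from compound 3 to compound 4 (0.15 log units; within the scatter). For compound 4 the expected value is 9000 nM, within an estimated range of 3500 nM to 25000 nM.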

Compound 4, half-maximal inhibitory concentration: 220 nM
The estimate for compound 4 lay 41-fold (1.61 log units) above the measured number; measured number outside the range, below it.
By their numbers in this assay, from the lowest: compound 4; then compound 1; then compounds 3 and 2 (each within the scatter of the next).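

In this assay, among the compounds shown here, the step of a 57-fold lower number from compound 3 to compound 4 (1.76 log units; beyond the scatter) is the first change in a single place on the shared core, and it shows that the formyl group on this double-bonded ring carbon is not required for activity. The earlier compounds shown here differ from one another in more than one place, so they could not show this position alone; here, (pyrrolidin-1-yl)methyl, with six heavy atoms where formyl had two, is accepted at this ring carbon, and the group placed there can shift the number by a large margin. Nothing in the data at hand explains the size of this step.

Going by these compounds, only one amine stands at this position, so it remains open whether the step depends on the pyrrolidine ring or would also appear with an open-chain group such as dimethylaminomethyl, a morpholin-4-ylmethyl group or a hydroxymethyl group with no nitrogen at all. On these data alone, it also remains open whether the same replacement would give a comparable step on a compound carrying the acetyloxy or methoxy groups of compound 1 or compound 2.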